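The source may hold more compounds than are shown below. What is called first, only, known or untested is meant among the compounds shown, and "the series" means these compounds.

Measured in a physicochemical assay for lipophilicity, at pH 7.4; a higher number here means a more lipophilic compound, a lower number a more polar compound:
- Compound 1 (`CCn1c(-c2nnc(N(C)Cc3ccc4nccn4c3)o2)nc2ccccc21`): 3
- Compound 2 (`CNC(=O)c1sc(N2CC3CC2(CNC(=O)c2c[nH]c4ncc(C(F)(F)F)cc24)C3)nc1C(F)(F)F`): 4.2

Compound 2 stands at 4.2, the higher of the two numbers, while compound 1 gives 3, a gap beyond the scatter. For the measured compounds named here, these two compounds do not differ in just one place, so the data hold no measured step between close relatives.

Compound 3 (`CNC(=O)c1sc(N2CC3CC2(CNC(=O)c2c[nH]c4ncccc24)C3)nc1C(F)(F)F`) is still to be measured in this assay. It departs from compound 2 in one place, with hydrogen in place of trifluoromethyl on an aromatic carbon. Going by the values given here, with no measured step to go by, the expectation rests on this structural change alone. A fall beyond the scatter is expected, estimated as a number 0.80 log units lower from compound 2 to compound 3 (beyond the scatter). For compound 3 the estimated value is 3.4, with an expected range of 3 to 3.8.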

Compound 3, distribution coefficient: 3.1
Estimate against measurement, compound 3: 0.30 log units above, within the range that was stated.
By their numbers in this assay, from the lowest: compounds 1 and 3 (each within the scatter of the next); then compound 2.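

The earlier compounds shown here differed in more than one place, so this assay offered no step between close relatives until this pair, in which hydrogen in place of trifluoromethyl on an aromatic carbon gives a number 1.10 log units lower from compound 2 to compound 3 (beyond the scatter). With the rest of the structure unchanged, this step is tied to a single position, on the six-membered aromatic ring with 1 nitrogen, and it is a large one. Nothing measured here accounts for its size.

Going by these compounds, only hydrogen and trifluoromethyl are seen at this position, so it remains open where a chlorine atom, a methoxy group or an amine would fall on the same scale. The compounds also leave open whether replacing the other trifluoromethyl, which compound 2 and compound 3 share, with hydrogen would give a step of similar size.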